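Ethynyl in place of fluoro: compound 2 to compound 4

The compounds below may be only part of what the source reports. "The series", "measured", "known", "first", "only" and "open" are said of these compounds alone.

In an ADME assay on microsomes from liver (Mus musculus) for metabolic stability, read by LC-MS, using NADPH, with a stated time of 10 min, tested at 0.1 uM (a lower number here means slower removal, a higher number faster removal of the compound), compound 1 `COc1ccc(F)cc1N1C(=O)CSC1c1cccc(C(=O)NCCCCn2cccn2)c1` gives 1310 mL.min-1.g-1 and compound 2 `COc1ccccc1N1C(=O)CSC1c1cc(F)cc(C(=O)NCCCCc2ccccc2)c1` gives 1430 mL.min-1.g-1 while compound 3 `COc1ccc(F)cc1N1C(=O)CSC1c1cccc(C(=O)NCCCCc2ccccc2)c1` gives 2250 mL.min-1.g-1 on the same scale. Compound 2 lies within the scatter of both other compounds, so the three cannot be ranked. Compound 4 `C#Cc1cc(C(=O)NCCCCc2ccccc2)cc(C2SCC(=O)N2c2ccccc2OC)c1` differs from compound 2 by ethynyl in place of fluoro on an aromatic carbon with the rest of the structure unchanged. Among the compounds with values here, the only measured step between two compounds differing in one place is a 1.7-fold higher number from compound 1 to compound 3 (0.23 log units; within the scatter) and it lies within the scatter. Within the data shown here, that step, phenyl in place of 1H-pyrazol-1-yl on a saturated chain carbon, does not touch the aromatic carbon changed here, and no ethynyl compound has been measured. No step beyond the scatter is therefore expected in this assay and no firm direction can be given. The estimate amounts to a 1.1-fold higher number from compound 2 to compound 4 (0.05 log units; within the scatter) as an expected change. Compound 4 is expected at 1600 mL.min-1.g-1 with an estimated range from 850 mL.min-1.g-1 to 3000 mL.min-1.g-1 for this measurement.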

Compound 4, intrinsic clearance in microsomes: 2490 mL.min-1.g-1
Compound 4: the middle estimate sits 1.6-fold (0.19 log units) below what was measured, within the range that was stated.
By their numbers in this assay, from the lowest: compounds 1, 2, 3 and 4 (each within the scatter of the next).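

Within the data shown here, the exchange of fluoro for ethynyl gives the first measured step on this aromatic carbon, meta to two large groups, and in this assay it reads a 1.7-fold higher number from compound 2 to compound 4 (0.24 log units; within the scatter). The earlier step changed only the far end of the chain, so this one adds that a fluorine atom can give way to two carbon atoms and a triple bond here without a difference that the assay can separate from the usual scatter. Nothing available here accounts for the result, so it stands as a bare observation.

Going by these compounds, it remains open whether a nitrile, a carboxylic acid or an amine on this carbon would give a step beyond the scatter. On these data alone, it is equally open whether a longer chain ending in a triple bond would read like ethynyl.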